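The source may report more compounds than this note shows. Statements on the series, on what has been measured and on what is new or still open speak of the compounds shown alone.

Measured so far:
compound 1 `Nc1scc(CN2CCN(c3cccc(F)c3)CC2)c1C(=O)c1ccc(Cl)cc1` — -37%
compound 2 `Nc1scc(CN2CCN(c3cc(F)cc(F)c3)CC2)c1C(=O)c1ccc(Cl)cc1` — -5%

In a functional assay on CHO cells with adenosine receptor A1 (Homo sapiens) as the target, read by cAMP accumulation and immunoassay, with a stated time of 6 min, tested at 0.1 uM (a lower number here means a stronger effect, a higher number a weaker effect of the compound at the concentration tested), compound 2 gives -5%, the highest of the two numbers; compound 1 gives -37%, a number that lies lower by a step beyond the scatter. Compound 3 `Nc1scc(CN2CCN(CCCc3ccc(Cl)cc3)CC2)c1C(=O)c1ccc(Cl)cc1` differs from compound 2 by 3-(4-chlorophenyl)propyl in place of 3,5-difluorophenyl on an amine nitrogen in a ring. Among the measured compounds shown here, the only measured step, a number 32 percentage points higher from compound 1 to compound 2 (beyond the scatter), concerns a change at a different place and gives no guide to this replacement. For the measured compounds named here, with no direct precedent, the expected step is a number 10 percentage points lower from compound 2 to compound 3 (within the scatter), with wide uncertainty in either direction. Compound 3 is therefore estimated at -15%, within a range from -45% to 15%.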

Compound 3, a percentage reported as activity, at one concentration (the size of the read-out at that concentration, not a potency): -3%
Compound 3: middle estimate off by 12 percentage points, on the low side; the measured number falls inside the stated range.
By their numbers in this assay, from the lowest: compound 1; then compounds 2 and 3 (each within the scatter of the next).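

In this assay, 3-(4-chlorophenyl)propyl and 3,5-difluorophenyl on the amine nitrogen in the ring cannot be told apart, with a number 2 percentage points higher from compound 2 to compound 3 (within the scatter). Set against 3-fluorophenyl at the same nitrogen, the same replacement gives a number 34 percentage points higher from compound 1 to compound 3 (beyond the scatter), so compound 1 stands apart from both other compounds. Nothing at hand explains either step.

Still open, from the compounds shown here alone, is whether the propyl chain or the ring halogen matters at this nitrogen. Unsubstituted 3-phenylpropyl, benzyl or 3-(3-fluorophenyl)propyl there would separate the two.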